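The compounds below may be only part of what the source reports. "The series", "measured", "known", "first", "only" and "open" are said of these compounds alone.

In a functional assay on SK-OV-3 cells (Homo sapiens) for cytotoxicity, read by MTT assay, with a stated time of 48 h (a higher number here means a weaker inhibitor, a lower number a stronger inhibitor), compound 1 `CC(C)COc1ccc2c(Cl)ccnc2c1` gives 3190 nM. Compound 3 `C=CCOc1ccc2c(Cl)ccnc2c1` gives 4030 nM in this assay. Compound 2 `CCCCCCOc1ccc2c(Cl)ccnc2c1` reaches only the limit of this assay, > 10000 nM (the limit of > 10000 nM in this assay, at which 1 of the 3 values shown sits). Of the two plain numbers, compound 3 and compound 1 sit within the scatter of each other, the gap being a 1.3-fold higher number from compound 1 to compound 3 (0.10 log units; within the scatter); the third value is a limit and not a number.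

Compound 4 `CC(C)Oc1ccc2c(Cl)ccnc2c1` has not yet been measured. It differs from compound 3 in one place: isopropyl in place of allyl on an oxygen on an aromatic ring. Within the data shown here, three measured steps bear on this. The step of a 1.3-fold higher number from compound 1 to compound 3 (0.10 log units; within the scatter) exchanges a branched three-carbon group for an unsaturated one on the chain carbon and stays within the scatter. The steps of an at least 3.1-fold higher number from compound 1 to compound 2 (0.49 log units; beyond the scatter) and an at least 2.4-fold lower number from compound 2 to compound 3 (0.39 log units; beyond the scatter) show that lengthening the chain to pentyl moves the value to the limit, while the shorter groups remain as plain numbers. Compound 4 keeps the same count of three carbon atoms as compound 3 and only trades the double bond for branching, so the expected step is a 1.2-fold lower number from compound 3 to compound 4 (0.06 log units; within the scatter), none beyond the scatter. Compound 4 is therefore estimated at 3500 nM in this assay, within a range from 1500 nM to 8500 nM.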

Compound 4, half-maximal inhibitory concentration: 3060 nM
Estimate against measurement, compound 4: 1.1-fold (0.06 log units) above; low and high end bracket the measured number.
By their numbers in this assay, from the lowest: compounds 4, 1 and 3 (each within the scatter of the next). At a limit, above all of these: compound 2.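

In this assay, compound 4 shows that at this oxygen on an aromatic ring, the change from allyloxy to isopropoxy removes the double bond and leaves the count of carbon atoms unchanged without moving the result outside the scatter, a 1.3-fold lower number from compound 3 to compound 4 (0.12 log units; within the scatter). Isopropyl and isobutyl on this oxygen likewise cannot be told apart, a 1.0-fold lower number from compound 1 to compound 4 (0.02 log units; within the scatter), so the three short groups now form a set with no order among them, whether the group is branched or carries a double bond. The one new step beyond the scatter, an at least 3.2-fold lower number from compound 2 to compound 4 (0.51 log units; beyond the scatter), starts from compound 2, whose value is a limit and not a number: the limit of > 10000 nM in this assay, at which 1 of the 4 values shown sits.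

The compounds shown leave open how the value behaves for a straight butyl or pentyl chain on this oxygen, and so at what chain length the plain numbers give way to the limit. They also leave open whether an amine or a carboxylic acid at the end of such a chain would give a number that differs from those of the plain carbon groups.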